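The compounds below may be only part of what the source reports. "The series", "measured", "known", "first", "only" and "open" are said of these compounds alone.

Among the measured compounds shown here, compound 3 `CCc1nc(NC(CC)CC)c(OC)nc1-c1ccc(Cl)cc1Cl` gives the lowest number so far in an assay on IMR-32 cells for displacement of a labelled ligand from corticotropin-releasing factor receptor 1 (Homo sapiens), read by scintillation counting, with a stated time of 2 h (on this read-out lower numbers stand for stronger inhibition and higher numbers for weaker inhibition), at 5.9 nM. Compound 1 `CCC(CC)Nc1nc(OC)c(-c2ccc(Cl)cc2Cl)nc1C` gives 14.4 nM in this assay, and compound 2 `CCOc1nc(-c2ccc(Cl)cc2Cl)c(CC)nc1NC(CC)CC` gives 151 nM. Compound 4 `CCC(CC)Nc1nc(OC)c(-c2ccc(Cl)cc2Cl)nc1OC` differs from compound 3 by methoxy in place of ethyl on an aromatic carbon. For the measured compounds named here, the one measured step, a 26-fold lower number from compound 2 to compound 3 (1.41 log units; beyond the scatter), concerns a different place on the shared core, so it does not speak directly to this change. The values of compound 1 and compound 3 show that methyl and ethyl at this place give numbers a little apart. A moderate rise in the number is therefore expected, a 2.5-fold higher number from compound 3 to compound 4 (0.41 log units; beyond the scatter), without strong grounds. Compound 4 is estimated at 15 nM, with a range from 4 nM to 60 nM.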

Compound 4, inhibition constant: 8.4 nM
Estimate against measurement, compound 4: 1.8-fold (0.25 log units) above, and the stated range covers the measured number.
By their numbers in this assay, from the lowest: compounds 3, 4 and 1 (each within the scatter of the next, the first and the last beyond it); then compound 2.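

Methoxy, with the hydrogen-bond acceptor it adds, can take the place of either alkyl group at this aromatic carbon without a clear change in this assay. The number stays within the scatter whether methoxy replaces ethyl (a 1.4-fold higher number from compound 3 to compound 4 (0.15 log units; within the scatter)) or methyl (a 1.7-fold lower number from compound 1 to compound 4 (0.23 log units; within the scatter)), so methyl, ethyl and methoxy cannot be told apart here. No supporting data explain this tolerance. The compounds shown leave open whether a longer chain, such as butyl, would stay in this range. They also leave open how an amine or a carboxylic acid would fare at this place.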